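Sulfonyl substituent and stability across the shared core

This account rests on a few compounds, and the source may have more. Where it says the series, first, only, none or still open, it means among the compounds named here.

Compound 3 `O=C(NS(=O)(=O)C1CC1)c1ccc(Nc2nc(NC3(c4ccc(Cl)cc4)CC3)nc(OCC(F)(F)F)n2)cc1` holds the highest of the three numbers in an ADME assay on microsomes from liver (Homo sapiens) for metabolic stability, with a stated time of 10 min; a higher number here means that more of the compound is left, a lower number that less of the compound is left: compound 3 gives 100%. Compound 1 `CC(C)C(=O)NCCS(=O)(=O)NC(=O)c1ccc(Nc2nc(NC3(c4ccc(Cl)cc4)CC3)nc(OCC(F)(F)F)n2)cc1` gives 86% in this assay, and compound 2 `CC(C)(C)CNCCS(=O)(=O)NC(=O)c1ccc(Nc2nc(NC3(c4ccc(Cl)cc4)CC3)nc(OCC(F)(F)F)n2)cc1` gives 89%; the step of a number 3 percentage points higher from compound 1 to compound 2 (within the scatter) stays within the scatter. Both steps that lead to compound 3 lie beyond the scatter and are modest in size: a number 14 percentage points higher from compound 1 to compound 3 (beyond the scatter) and a number 11 percentage points higher from compound 2 to compound 3 (beyond the scatter).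

Compound 4 `CC(=O)NCCS(=O)(=O)NC(=O)c1ccc(Nc2nc(NC3(c4ccc(Cl)cc4)CC3)nc(OCC(F)(F)F)n2)cc1` is not yet measured. It differs from compound 3 in one place: 2-acetamidoethyl in place of cyclopropyl on a sulfonyl sulfur. This runs the two measured steps the other way, returning a chain on the sulfonyl sulfur in place of the three-membered ring, now as 2-acetamidoethyl rather than the longer chains of compound 1 and compound 2. Since both steps toward the cyclopropyl were modest and pointed the same way, a modest fall is expected for the reverse, a number 14 percentage points lower from compound 3 to compound 4 (beyond the scatter), beyond the scatter but not large. Compound 4 is therefore estimated to give 86% in this assay, within a range from 74% to 96%.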

Compound 4, percent of the compound remaining: 95%
For compound 4 the middle estimate is 9 percentage points below the measured one, and the stated range covers the measured number.
By their numbers in this assay, from the lowest: compounds 1, 2, 4 and 3 (each within the scatter of the next, the first and the last beyond it).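

In this assay, 2-acetamidoethyl in place of cyclopropyl on the sulfonyl sulfur gives a number 5 percentage points lower from compound 3 to compound 4 (within the scatter), so this chain cannot be told apart from the three-membered ring, which the chains of compound 1 and compound 2 did not show. Among the chains, methyl in place of isopropyl on a carbonyl carbon gives a number 9 percentage points higher from compound 1 to compound 4 (within the scatter) and acetyl in place of neopentyl on an amine nitrogen gives a number 6 percentage points higher from compound 2 to compound 4 (within the scatter), so these changes at the chain end also cannot be told apart. Nothing available explains these readings.

Still open, from the compounds shown here alone, is how a chain ending in a primary amine or a carboxylic acid would read on the sulfonyl sulfur. Going by these compounds, a plain methyl there is equally open, as is whether a longer incubation would separate these compounds.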